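The source may hold more compounds than are shown below. What is called first, only, known or untested is meant among the compounds shown, and "the series" means these compounds.

In a functional assay on PC-3 cells (Homo sapiens) for inhibition, read by sulforhodamine B assay (on this read-out higher numbers stand for weaker inhibition of growth and lower numbers for stronger inhibition of growth), three compounds have been measured:
Compound 1 `Cc1ccc2[nH]c(-c3ccc(-c4ccc(-c5cccc(Cl)c5)cc4)cc3)nc2c1` gives 2670 nM
Compound 2 `Clc1cccc(-c2ccc(-c3ccc(-c4nc5ccccc5[nH]4)cc3)cc2)c1` gives 33700 nM
Compound 3 `COc1ccc(-c2ccc(-c3ccc(-c4nc5c(O)cccc5[nH]4)cc3)cc2)cc1OC` gives 1240 nM

Compound 1 holds the second highest of these three numbers, with compound 3 lower and compound 2 higher. Compound 4 `Cc1ccc2[nH]c(-c3ccc(-c4ccc(-c5ccc(C(F)(F)F)cc5)cc4)cc3)nc2c1` keeps the core of compound 1 and takes 4-(trifluoromethyl)phenyl in place of 3-chlorophenyl on an aromatic carbon. For the measured compounds named here, only one measured step exists here (a 13-fold higher number from compound 1 to compound 2 (1.10 log units; beyond the scatter)). It is large, but it is hydrogen in place of methyl on an aromatic carbon, and the 3-chlorophenyl stays untouched. Compound 3 carries neither of the two exchanged groups and also differs in the core, so it cannot isolate this exchange. Going by the values given here, no measured step therefore speaks directly to the change, and the data give no direction for it. No step beyond the scatter is expected in this assay, but the range is kept wide, since compound 2 moved far from compound 1 on a single small change (a 13-fold higher number from compound 1 to compound 2 (1.10 log units; beyond the scatter)). On these data alone, the expected step is a 1.1-fold higher number from compound 1 to compound 4 (0.05 log units; within the scatter) and its direction remains open. Compound 4 is expected at 3000 nM (estimated range 800 nM to 12000 nM).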

Compound 4, concentration for 50% growth inhibition: 2010 nM
Beside the measured number, compound 4's estimate is 1.5-fold (0.17 log units) above it, and the stated range covers the measured number.
By their numbers in this assay, from the lowest: compounds 3, 4 and 1 (each within the scatter of the next, the first and the last beyond it); then compound 2.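

Read in this assay, the exchange of 3-chlorophenyl for 4-(trifluoromethyl)phenyl on the core of compound 1 gives a 1.3-fold lower number from compound 1 to compound 4 (0.12 log units; within the scatter), the first step seen at this position, and it stays within the scatter. For the compounds shown here, the position therefore accepts two different substituted phenyl groups, one of them with more heavy atoms, with no measurable change in growth inhibition, whereas the only earlier step, a 13-fold higher number from compound 1 to compound 2 (1.10 log units; beyond the scatter), came from hydrogen in place of methyl elsewhere on the molecule and was large. Nothing measured here on these compounds offers an explanation for this flat result.

The compounds shown leave open whether this tolerance extends beyond halogen- and fluorine-bearing phenyl groups, for instance to a phenyl ring carrying an amine or a carboxylic acid, or to a plain phenyl ring with no substituent at all. They also leave open whether 4-(trifluoromethyl)phenyl would behave the same way on the core of compound 2, which lacks the methyl, or on the core of compound 3, which carries a hydroxyl group.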